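Methyl on the fused ring of the pyridine-linked acid

The compounds below may be only part of what the source reports. "The series", "measured", "known", "first", "only" and "open" are said of these compounds alone.

Measured so far:
- compound 1, `CC1(C)CCC(C)(C)c2cc(-c3cccc(-c4ccc(C(=O)O)cc4)c3)ccc21`; in an assay on CV-1 cells (Cercopithecidae) for activation of retinoic acid receptor beta (Homo sapiens) (a higher number here means that more compound is needed for the effect, a lower number that less compound is needed), compound 1 gives 4.3 nM.
- compound 2, `Cc1ccc(-c2ccc(C(=O)O)cc2)cc1-c1ccc2c(c1)C(C)(C)CCC2(C)C`; in this assay compound 2 reaches only the assay limit, < 1 nM.
- compound 3, `CC1(C)CCC(C)(C)c2cc(-c3cccc(-c4ccc(C(=O)O)cc4)n3)ccc21`; in this assay compound 3 gives 140 nM.

Compound 3 carries the highest of the two numbers shown; its nearest neighbour is compound 1, which lies well below it, beyond the scatter. The third value is a limit, not a number.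

Going by the values given here, one measured step touches a methyl on an aromatic carbon: an at least 4.3-fold lower number from compound 1 to compound 2 (0.63 log units; beyond the scatter). Its size is only bounded from one side, because the end point sits at the limit of < 1 nM in this assay, at which 1 of the 3 values shown sits.

Compound 4, `Cc1cc2c(cc1-c1cccc(-c3ccc(C(=O)O)cc3)n1)C(C)(C)CCC2(C)C`, differs from compound 3 by methyl in place of hydrogen on an aromatic carbon. Among the compounds with values here, the measured methyl step sits on a different ring, so it bears on the new step only loosely; still, it is the only guide and it points downward. A modest lowering, with wide uncertainty, is therefore the expectation: the step is estimated as a 2.8-fold lower number from compound 3 to compound 4 (0.45 log units; beyond the scatter). For compound 4 the estimated value in this assay is 50 nM, expected to fall between 10 nM and 250 nM.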

Compound 4, concentration for half-maximal activity: > 1000 nM
Compound 4 gave a limit, no number; the forecaster's own chance of this, stated with the estimate: 2%; middle value at least 20-fold (1.30 log units) away from the limit.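

In this assay, methyl in place of hydrogen on an aromatic carbon of the fused ring system, ortho to a large group, costs much activity, with an at least 7.1-fold higher number from compound 3 to compound 4 (0.85 log units; beyond the scatter). Going by these compounds, compound 4 reaches only a limit of the assay, > 1000 nM, and not a number, so this step is bounded from one side and its full size stays unknown. The methyl change has no single direction in this series, and the step on the other ring gives no reliable guide to this position: the same change on two cores in this assay, an at least 4.3-fold lower number (0.63 log units; beyond the scatter) from compound 1 to compound 2 and an at least 7.1-fold higher number (0.85 log units; beyond the scatter) from compound 3 to compound 4, at least 30-fold (1.48 log units) apart, beyond the scatter of two such steps.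

Open, on these data alone, is whether the same methyl, at this place on the core of compound 1, would also raise the number, or whether the step holds only on the core of compound 3. Also open, as far as these compounds go, is whether a fluorine, an ethyl or a methoxy on this aromatic carbon would give a step in the same direction as the methyl, and whether any of these would stay within reach of the assay's measurable range.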